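Removing a methoxy from compound 3

The compounds below may be only part of what the source reports. "The series", "measured", "known", "first", "only" and "open" are said of these compounds alone.

In a functional assay on HCT-116 cells (Homo sapiens) for cytotoxicity, read by sulforhodamine B assay, with a stated time of 48 h (a lower number here means a stronger inhibitor, a higher number a weaker inhibitor), compound 1 (`COc1cc(/C=C/C(=O)/C=C/c2cccs2)ccc1OCc1cn(CCOc2cc(=O)oc3ccccc23)nn1`) gives 9290 nM and compound 2 (`COc1cccc(/C=C/C(=O)/C=C/c2ccc(OCc3cn(CCOc4cc(=O)oc5ccccc45)nn3)c(OC)c2)c1`) gives 9760 nM while compound 3 (`COc1cc(/C=C/C(=O)/C=C/c2cc(OC)c(OC)c(OC)c2)ccc1OCc1cn(CCOc2cc(=O)oc3ccccc23)nn1`) gives 2210 nM as the lowest of the three numbers. Compound 4 (`COc1ccc(/C=C/C(=O)/C=C/c2ccc(OCc3cn(CCOc4cc(=O)oc5ccccc45)nn3)c(OC)c2)cc1OC`) differs from compound 3 by hydrogen in place of methoxy on an aromatic carbon, so 3,4,5-trimethoxyphenyl becomes 3,4-dimethoxyphenyl. The closest guide is a 4.4-fold lower number from compound 2 to compound 3 (0.65 log units; beyond the scatter) on going from 3-methoxyphenyl to 3,4,5-trimethoxyphenyl, and a 4.2-fold lower number from compound 1 to compound 3 (0.62 log units; beyond the scatter) is similar in size. Compound 4 keeps part of that methoxy difference, so a rise smaller than those steps is expected. The expected step is a 2.3-fold higher number from compound 3 to compound 4 (0.35 log units; beyond the scatter) in this estimate. Compound 4 is estimated at 5000 nM within an expected range of 2200 nM to 11000 nM.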

Compound 4, half-maximal inhibitory concentration: 4710 nM
The estimate for compound 4 lay 1.1-fold (0.03 log units) above the measured number; measured number inside the range.
By their numbers in this assay, from the lowest: compound 3; then compounds 4, 1 and 2 (each within the scatter of the next, the first and the last beyond it).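

In this assay, the ring position ortho to a methoxy group now reads as one step of a series: removing that methoxy from the 3,4,5-trimethoxyphenyl group gives a 2.1-fold higher number from compound 3 to compound 4 (0.33 log units; beyond the scatter). Adding a methoxy to the 3-methoxyphenyl group gives a 2.1-fold lower number from compound 2 to compound 4 (0.32 log units; beyond the scatter), so each added methoxy in this series of three counts. The 3,4-dimethoxyphenyl group is not separated from thiophen-2-yl, with a 2.0-fold lower number from compound 1 to compound 4 (0.29 log units; within the scatter).

Going by these compounds, whether an ethoxy group or an amine at this position would serve as well as methoxy stays open. Nothing available explains these differences.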